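The compounds below may be only part of what the source reports. "The series", "measured", "known", "first", "only" and "open" are said of these compounds alone.

Compound 1 `Cc1ccc(C(=O)Nc2cccc3cccnc23)cn1`, in a functional assay on PANC-1 cells (Homo sapiens) for inhibition, read by MTT assay, with a stated time of 72 h; on this read-out higher numbers stand for weaker inhibition and lower numbers for stronger inhibition: > 10000 nM, which is a limit of the assay.
Compound 2 `O=C(Nc1cccc2cccnc12)c1ccc(Br)nc1`, in this assay: > 10000 nM, which is also a limit of the assay.

Compound 2 thus stands at the limit of > 10000 nM in this assay, at which 2 of the 2 values shown sit. Among the compounds with values here, the only recorded step, a step that the two limits leave unreadable from compound 1 to compound 2, is consequently unreadable in size. Compound 3 `O=C(Nc1cccc2cccnc12)c1ccc(F)nc1` differs from compound 2 by fluoro in place of bromo on an aromatic carbon. Within the data shown here, no measured step resolves a change of this kind, so nothing beyond the scatter can be expected in either direction. Compound 3 is therefore expected to stay near the same limit, estimated at 15000 nM, in a range from 3000 nM to 60000 nM. The step that the limit leaves unreadable from compound 2 to compound 3 is expected to be small.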

Compound 3, half-maximal inhibitory concentration: > 10000 nM
Compound 3: only a limit was reported (the forecaster's own chance of this, stated with the estimate: 80%); the middle value lies beyond the limit too.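

Within the data shown here, no step among compound 1, compound 2 and compound 3 can be read in this assay, since all three sit at a limit: the limit of > 10000 nM in this assay, at which 3 of the 3 values shown sit. As far as these compounds go, how far each compound lies beyond that limit, and whether methyl, bromo or fluoro makes any difference, remains open.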